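Ethoxycarbonyl for sulfamoyl: compound 2 to compound 3

This account rests on a few compounds, and the source may have more. Where it says the series, first, only, none or still open, it means among the compounds named here.

Measured so far in a functional assay on BXPC-3 cells (Homo sapiens) for cytotoxicity, read by MTT assay, with a stated time of 72 h; on this read-out higher numbers stand for weaker inhibition and lower numbers for stronger inhibition:
compound 1 `O=C1C(Nc2ccc(OC(F)(F)F)cc2)=CC(=O)c2ncncc21` gives 900 nM;
compound 2 `NS(=O)(=O)c1ccc(NC2=CC(=O)c3ncncc3C2=O)cc1` gives > 10000 nM, which is a limit of this assay and not a number.

Compound 2 therefore stands at the weak end of what has been seen, at the limit of > 10000 nM in this assay, at which 1 of the 2 values shown sits. Among the compounds with values here, the step leading to it, an at least 11-fold higher number from compound 1 to compound 2 (1.04 log units; beyond the scatter), is the only measured step and shows that the shared core loses much on carrying sulfamoyl in place of trifluoromethoxy. Compound 3 `CCOC(=O)c1ccc(NC2=CC(=O)c3ncncc3C2=O)cc1` differs from compound 2 by ethoxycarbonyl in place of sulfamoyl on an aromatic carbon. Within the data shown here, no measured step covers ethoxycarbonyl itself; the one that bears on the change is the loss of sulfamoyl, which is the group whose arrival cost at least the size seen from compound 1 to compound 2. Compound 3 is expected to move back toward compound 1 only partly, by an at least 2.5-fold lower number from compound 2 to compound 3 (0.39 log units; beyond the scatter). Compound 3 is estimated at 4000 nM, with a range of 1200 nM to 12000 nM.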

Compound 3, half-maximal inhibitory concentration: 5900 nM
The estimate for compound 3 lay 1.5-fold (0.17 log units) below the measured number; low and high end bracket the measured number.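

In this assay, ethoxycarbonyl in place of trifluoromethoxy on this aromatic carbon gives a 6.6-fold higher number from compound 1 to compound 3 (0.82 log units; beyond the scatter), so a second group at this position falls short of trifluoromethoxy, this time with a number at both ends of the step. Against sulfamoyl, the change reads as an at least 1.6-fold lower number from compound 2 to compound 3 (0.22 log units; that floor lies within the scatter), and that floor alone does not separate ethoxycarbonyl from sulfamoyl. Compound 2 carries a limit of the assay and not a number: the limit of > 10000 nM in this assay, at which 1 of the 3 values shown sits.

Going by these compounds, how far sulfamoyl and ethoxycarbonyl truly lie apart remains open, and a compound 2 value would be needed to settle it. Also open, on these data alone, is whether a smaller group on the same aromatic carbon, such as an amine, a carboxylic acid or a trifluoromethyl, would come closer to trifluoromethoxy than ethoxycarbonyl does.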